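Carbamate ester homologation in a dihydropyrimidine calcium channel series

This account rests on a few compounds, and the source may have more. Where it says the series, first, only, none or still open, it means among the compounds named here.

Measured compounds:
compound 1 `COC(=O)N1C(=S)NC(C)=C(C(=O)OC(C)C)C1c1cccc([N+](=O)[O-])c1` gives 550 nM
compound 2 `CCOC(=O)N1C(=O)NC(C(C)C)=C(C(=O)OC)C1c1cccc([N+](=O)[O-])c1` gives 24500 nM

Of the compounds shown here, two have been measured in an assay on HEK293 cells for antagonist activity at Voltage-dependent L-type calcium channel subunit alpha-1D (Rattus norvegicus), read by FLIPR; a higher number here means a weaker inhibitor, a lower number a stronger inhibitor. Compound 2 holds the highest of the two numbers; its nearest neighbour is compound 1, whose number is lower by a gap well beyond the usual scatter. Compound 2 thus stands as the weaker inhibitor of the pair. Compound 3 `COC(=O)C1=C(C(C)C)NC(=O)N(C(=O)OC(C)C)C1c1cccc([N+](=O)[O-])c1` has not yet been measured. It differs from compound 2 by methyl in place of hydrogen on a saturated chain carbon bound to an oxygen next to a carbonyl group and a saturated chain carbon, which amounts to ethoxycarbonyl becoming isopropoxycarbonyl on the ring nitrogen. Within the data shown here, no measured pair shows this exact change, so there is no directly comparable step. A single carbon added at this place is expected to move the value little, if at all, with a step from compound 2 to compound 3 of a 1.2-fold lower number from compound 2 to compound 3 (0.09 log units; within the scatter) that is expected to stay within the scatter. Compound 3 is therefore estimated at 20000 nM, with a range from 6000 nM to 60000 nM.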

Compound 3, half-maximal inhibitory concentration: 10100 nM
Compound 3: middle estimate off by 2.0-fold (0.30 log units), on the high side; measured number inside the range.
By their numbers in this assay, from the lowest: compound 1; then compound 3; then compound 2.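

In this assay, among these compounds, ethoxycarbonyl becoming isopropoxycarbonyl on the ring nitrogen gives a 2.4-fold lower number from compound 2 to compound 3 (0.38 log units; beyond the scatter) and is the only single-place step in this set, modest in size but beyond the scatter. It shows that this position responds to a small change: one methyl on the saturated chain carbon bound to the oxygen is enough to lower the number, and the branched ester is the stronger inhibitor of this pair. Nothing available accounts for the shift.

On these data alone, whether a tert-butyl ester, a longer chain or an amine carried on the ester chain would lower the number further at this place stays open. A single step also cannot say whether the same change would act to a similar extent on the core of compound 1.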